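This account rests on a few compounds, and the source may have more. Where it says the series, first, only, none or still open, it means among the compounds named here.

Compound 2 `C[C@@H](NC(=O)c1ccc(C#Cc2ccc(F)cc2F)cn1)C(C)(C)O` gives 38.2% in an ADME assay on HEK293 cells for agonist activity at metabotropic glutamate receptor 5 (Rattus norvegicus), read by fluorescence and calcium flux; a higher number here means a larger maximal response, a lower number a smaller maximal response. Its nearest neighbour is compound 1 `C[C@@H](NC(=O)c1ccc(C#Cc2ccc(F)cc2)cn1)C(C)(C)O`, which reaches 38.4%, a gap of a number 0.2 percentage points lower from compound 1 to compound 2 (within the scatter). Compound 3 `C[C@@H](NC(=O)c1ccc(C#Cc2cccc(F)n2)cn1)C(C)(C)O` lies far off with 8.3%, a step of a number 29.9 percentage points lower from compound 2 to compound 3 (beyond the scatter). Compound 4 `C[C@@H](NC(=O)c1ccc(C#Cc2ccc(F)cn2)cn1)C(C)(C)O` is not yet measured; it differs from compound 2 in one place: 5-fluoropyridin-2-yl in place of 2,4-difluorophenyl on a triple-bonded carbon. Two earlier steps bear on this: a number 30.1 percentage points lower from compound 1 to compound 3 (beyond the scatter) put 6-fluoropyridin-2-yl in place of 4-fluorophenyl on a triple-bonded carbon, and a number 29.9 percentage points lower from compound 2 to compound 3 (beyond the scatter) did the same in place of 2,4-difluorophenyl, both sharply lowering the response. A comparable exchange here makes a drop expected in this assay, of about a number 24.2 percentage points lower from compound 2 to compound 4 (beyond the scatter). Compound 4 is therefore estimated at 14%, within 4% to 28%.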

Compound 4, largest response reached (reported as efficacy), in percent of the reference or control that the assay uses: 13.5%
For compound 4 the middle estimate is 0.5 percentage points above the measured one, within the range that was stated.
By their numbers in this assay, from the lowest: compounds 3 and 4 (each within the scatter of the next); then compounds 2 and 1 (each within the scatter of the next).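

In this assay, the loss seen with 6-fluoropyridin-2-yl on the triple-bonded carbon also appears with 5-fluoropyridin-2-yl (a number 24.7 percentage points lower from compound 2 to compound 4 (beyond the scatter); a number 24.9 percentage points lower from compound 1 to compound 4 (beyond the scatter)), so among these compounds, both rings with a hetero atom sit low and neither goes against this. Moving from one fluoropyridinyl group to the other does not separate the two compounds (a number 5.2 percentage points higher from compound 3 to compound 4 (within the scatter)). Nothing at hand explains why the response falls with these groups. From the compounds shown here alone, whether a pyrimidinyl group, or a pyridin-2-yl ring carrying methyl or a nitrile in place of fluorine, would give the same low response stays open.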